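Chloro to Nitro on the 4-Chlorophenyl Arm

The source may hold more compounds than are shown below. What is called first, only, known or untested is meant among the compounds shown, and "the series" means these compounds.

Compound 3 `COc1cc(N)c(Cl)cc1NC(=O)C1CCN(Cc2ccc(Cl)cc2)CC1` holds the lowest of the two numbers read here: in a functional assay on the whole organism for antagonist activity, with Mus musculus as the target (a lower number here means that less compound is needed, a higher number that more compound is needed for the effect), compound 3 gives 1.2 mg/kg, while compound 2 `COc1cc(N)c(Cl)cc1NC(=O)C1CCN(CC2CCCCC2)CC1` gives 2.9 mg/kg, so a 2.4-fold lower number from compound 2 to compound 3 (0.38 log units; beyond the scatter). Compound 1 `COc1cc(N)c(Cl)cc1NC(=O)C1CCN(CC2CC2)CC1` sits at the limit of > 10 mg/kg in this assay, at which 1 of the 3 values shown sits; its entry > 10 mg/kg is a limit, not a number. From it, an at least 3.4-fold lower number from compound 1 to compound 2 (0.53 log units; beyond the scatter) and an at least 8.3-fold lower number from compound 1 to compound 3 (0.92 log units; beyond the scatter). Compound 4 `COc1cc(N)c(Cl)cc1NC(=O)C1CCN(Cc2ccc([N+](=O)[O-])cc2)CC1` changes only the substituent on the arm: nitro in place of chloro on an aromatic carbon. Every measured step replaces the whole group on the saturated chain carbon bound to the amine nitrogen in a ring, so none bears directly on this change. Going by the values given here, with no step to lean on, a change within the scatter is expected, no change at the digits printed from compound 3 to compound 4 (within the scatter). Compound 4 is estimated at 1.2 mg/kg, in a range from 0.5 mg/kg to 3 mg/kg.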

Compound 4, dose for half-maximal effect: > 4 mg/kg
Compound 4: no number, only a limit (the forecaster's own chance of this, stated with the estimate: 5%); middle value at least 3.3-fold (0.52 log units) from the limit.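

In this assay compound 4 carries a limit, not a number: the limit of > 4 mg/kg in this assay, at which 1 of the 4 values shown sits.
With the rest of the arm unchanged, nitro in place of chloro gives an at least 3.3-fold higher number from compound 3 to compound 4 (0.52 log units; beyond the scatter) and so the number responds to the group on this aromatic carbon, not only to replacement of the whole arm. Against the cyclohexyl arm there is an at least 1.3-fold higher number from compound 2 to compound 4 (0.13 log units; that floor lies within the scatter) and no order follows, while the steps between compound 1 and compound 4 cannot be read.

On these data alone, how far compound 4 lies past its limit stays open. As far as these compounds go, whether chloro holds its place against a methoxy, an amine or a bromo on this aromatic carbon also stays open.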